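Replacing the amine tail: expected effect on cell growth

The compounds below may be only part of what the source reports. "The series", "measured", "known", "first", "only" and "open" are said of these compounds alone.

Measured so far in a functional assay on A549 cells (Homo sapiens) for antiproliferative activity, read by MTT assay, with a stated time of 72 h; on this read-out lower numbers stand for stronger inhibition and higher numbers for weaker inhibition:
- compound 1 `COc1cc2c(Nc3ccc(C#N)cc3)ncnc2cc1OCCCN(C)Cc1ccccc1`: > 100000 nM
- compound 2 `COc1cc2c(Nc3ccc(C#N)cc3)ncnc2cc1OCCCN1CCC(CO)CC1`: > 100000 nM
- compound 3 `COc1cc2c(Nc3ccc(C#N)cc3)ncnc2cc1OCCCN1CCC(N2CCCCC2)CC1`: 30700 nM

All three compounds share one core and differ only in the amine tail three bonds along the chain from the oxygen on the aromatic ring. For compound 1 the value is a limit of the assay, not a number. For compound 2 the value is likewise a limit. Compound 3 alone gives a real number in this assay, and it is therefore the only firm point among the three; the other two values sit at the limit of > 100000 nM in this assay, at which 2 of the 3 values shown sit. The steps of an at least 3.2-fold lower number from compound 1 to compound 3 (0.51 log units; beyond the scatter) and an at least 3.2-fold lower number from compound 2 to compound 3 (0.51 log units; beyond the scatter) are both beyond the scatter, while the step that the two limits leave unreadable from compound 1 to compound 2 cannot be read.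

Compound 4 `COc1cc2c(Nc3ccc(C#N)cc3)ncnc2cc1OCCCN1CCN(c2ccncc2)CC1` has not yet been measured. It differs from compound 3 in one place: 4-(pyridin-4-yl)piperazin-1-yl in place of 4-(piperidin-1-yl)piperidin-1-yl on a saturated chain carbon, three bonds along the chain from an oxygen on an aromatic ring. Among the compounds measured, only the 4-(piperidin-1-yl)piperidin-1-yl tail of compound 3 has produced a number. Given that the step of an at least 3.2-fold lower number from compound 2 to compound 3 (0.51 log units; beyond the scatter) came from altering only the group on the ring carbon of that tail, compound 4 is expected to give up part of that gain, an estimated step of a 2.0-fold higher number from compound 3 to compound 4 (0.29 log units; within the scatter). In this assay compound 4 is estimated at 60000 nM, with a range from 20000 nM to 100000 nM, and a fair chance that only a limit is reported.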

Compound 4, half-maximal inhibitory concentration: 25500 nM
Compound 4: middle estimate off by 2.4-fold (0.37 log units), on the high side; low and high end bracket the measured number.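

In this assay, putting 4-(pyridin-4-yl)piperazin-1-yl in place of 4-(piperidin-1-yl)piperidin-1-yl gives a 1.2-fold lower number from compound 3 to compound 4 (0.08 log units; within the scatter), so a second tail now yields a real number at this saturated chain carbon, and that number cannot be told apart from the first. The tail of compound 4 differs from that of compound 3 by a nitrogen in place of a carbon and by an aromatic ring in place of a saturated one, yet these changes together leave no readable difference in this assay. Measured against the other two tails, the change gives an at least 3.9-fold lower number from compound 2 to compound 4 (0.59 log units; beyond the scatter) and an at least 3.9-fold lower number from compound 1 to compound 4 (0.59 log units; beyond the scatter), so across these four compounds the two tails with two six-membered rings give numbers, while the two tails with one ring do not.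

Going by these compounds, whether a one-ring tail with a second nitrogen, such as 4-methylpiperazin-1-yl, or morpholine, or a longer chain would also give a number remains open. The true sizes of the steps from compound 1 and compound 2 also remain open, since each of these two compounds gives only a limit: the limit of > 100000 nM in this assay, at which 2 of the 4 values shown sit.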